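The source may report more compounds than this note shows. Statements on the series, on what has been measured and on what is new or still open speak of the compounds shown alone.

Compound 1 `COc1ccc(CN2CCN(c3nc(Nc4ccc(C#N)c(C(F)(F)F)c4)nc(Oc4ccnc5ccccc45)n3)CC2)c(OC)c1OC` — > 100000 nM
Compound 2 `CC(C)N1CCN(c2nc(Nc3ccc(C#N)c(C(F)(F)F)c3)nc(Oc3ccnc4ccccc34)n2)CC1` — > 100000 nM
Compound 3 `N#Cc1ccc(Nc2nc(Oc3ccnc4ccccc34)nc(N3CCN(c4ccccc4)CC3)n2)cc1C(F)(F)F` — > 100000 nM

In a functional assay on DU-145 cells (Homo sapiens) for cytotoxicity, read by sulforhodamine B assay, with a stated time of 48 h (a lower number here means a stronger inhibitor of growth, a higher number a weaker inhibitor of growth), compound 1 gives > 100000 nM, which is a limit of the assay rather than a number. Compound 2 likewise gives > 100000 nM, again a limit. Compound 3 gives > 100000 nM, also a limit. Compound 3 therefore stands at the limit where all the values shown sit (the limit of > 100000 nM in this assay, at which 3 of the 3 values shown sit); none of the three compounds shows measurable growth inhibition. Going by the values given here, the one measured step that changes a single place, a step that the two limits leave unreadable from compound 2 to compound 3, puts phenyl in place of isopropyl on an amine nitrogen in a ring; its size is not readable, as both ends are limits.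

Compound 4 `N#Cc1ccc(Nc2nc(Oc3ccnc4ccccc34)nc(N3CCN(c4ccccn4)CC3)n2)cc1C(F)(F)F` differs from compound 3 by pyridin-2-yl in place of phenyl on an amine nitrogen in a ring. Among the compounds with values here, no measured step with a readable size bears on this change, so the expectation rests only on where compound 3 stands. The step of a number no higher from compound 3 to compound 4 (the limit leaves the size open) is expected to be none beyond the scatter, and compound 4 is expected to remain at the limit. Compound 4 is estimated at 100000 nM, with a range from 30000 nM to 300000 nM.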

Compound 4, concentration for total growth inhibition: > 100000 nM
Compound 4: only a limit was reported (the forecaster's own chance of this, stated with the estimate: 85%); the middle value lies on the limit itself.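

The steps from compound 3 to compound 4 and from compound 2 to compound 4 cannot be read, as both ends of each are limits and not numbers: the limit of > 100000 nM in this assay, at which 4 of the 4 values shown sit. The compounds shown leave open whether any group on that ring nitrogen would give a measurable value in this assay.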